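Bromine removed from the aryl ring of compound 2

The source may report more compounds than this note shows. Statements on the series, on what has been measured and on what is new or still open speak of the compounds shown alone.

Two members of the series have numbers in an assay on isolated protein for binding affinity to histone acetyltransferase KAT2B (Homo sapiens), read by isothermal titration calorimetry; on this read-out lower numbers stand for tighter binding and higher numbers for weaker binding. Compound 1 `C=CCCn1c(N[C@@H]2C[C@H](c3ccccc3)CN(C)C2)nc2cc[nH]c2c1=O` gives 3410 nM in this assay. Compound 2 `CN1C[C@H](Nc2nc3cc[nH]c3c(=O)n2C)C[C@H](c2cccc(Br)c2)C1` gives 128 nM in this assay, the lowest of the two numbers; compound 1 sits well above it, and the gap is beyond the usual scatter. Compound 1 and compound 2 differ in two places at once, so the two numbers do not separate the share of either change.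

Compound 3 `CN1C[C@H](Nc2nc3cc[nH]c3c(=O)n2C)C[C@H](c2ccccc2)C1` is not yet measured. Relative to compound 2 the change is hydrogen in place of bromo on an aromatic carbon; the bromine sits on an aromatic carbon of a six-membered aromatic ring of carbon only, and the whole of the difference is the aryl group itself, 3-bromophenyl to phenyl. Within the data shown here, no step between measured compounds isolates this change. Compound 3 is expected to bind less tightly than compound 2, with a step of a 4.7-fold higher number from compound 2 to compound 3 (0.67 log units; beyond the scatter) in this assay, since compound 1 carries the same phenyl group and gives 3410 nM. The estimate for compound 3 is 600 nM, in a range from 200 nM to 2000 nM.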

Compound 3, dissociation constant: 152 nM
Compound 3: middle estimate off by 3.9-fold (0.60 log units), on the high side; the whole stated range lies above it.
By their numbers in this assay, from the lowest: compounds 2 and 3 (each within the scatter of the next); then compound 1.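

In this assay, the change from 3-bromophenyl to phenyl gives a 1.2-fold higher number from compound 2 to compound 3 (0.07 log units; within the scatter) in the series, so bromo and hydrogen cannot be told apart on this aromatic carbon with the shared core and the methyl group held fixed. With the phenyl group held fixed, the change described as hydrogen in place of allyl on a saturated chain carbon bound to an aromatic nitrogen gives a 22-fold lower number from compound 1 to compound 3 (1.35 log units; beyond the scatter) as a large step, which places the main difference among these compounds at that chain and not on the aryl ring. No measurement at hand gives a reason for either step.

From the compounds shown here alone, it remains open whether groups other than bromo on this aromatic carbon, such as methoxy, an amine or a carboxylic acid, would also leave the number within the scatter of the phenyl compound. Also open, going by these compounds, are how the number moves with an ethyl or propyl chain on the aromatic nitrogen, and whether the chain step holds with 3-bromophenyl in place of phenyl.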